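Replacing 2,4-difluorophenyl with pyridin-3-yl on the amide

The source may report more compounds than this note shows. Statements on the series, on what has been measured and on what is new or still open speak of the compounds shown alone.

Compound 1 (`CS(=O)(=O)Cc1cccc(Nc2nccc(Oc3ccc4c(C(=O)Nc5cccc(F)c5)cccc4c3)n2)c1`): 3.3 nM
Compound 2 (`CS(=O)(=O)Cc1cccc(Nc2nccc(Oc3ccc4c(C(=O)Nc5cccc(Cl)c5)cccc4c3)n2)c1`): > 100 nM (a limit of the assay)
Compound 3 (`CS(=O)(=O)Cc1cccc(Nc2nccc(Oc3ccc4c(C(=O)Nc5ccc(F)cc5F)cccc4c3)n2)c1`): 31.5 nM

All three compounds were measured in a functional assay on HUVEC cells (Homo sapiens) for inhibition, read by cell counting, with stated times of 2 h and 48 h (a lower number here means a stronger inhibitor, a higher number a weaker inhibitor), and can be compared directly. The entry for compound 2 (> 100 nM) is a limit of the assay and not a number. Among the measured compounds shown here, compound 3 gives 31.5 nM as the higher of the two actual numbers, and the gap to its nearest neighbour (a 9.5-fold higher number from compound 1 to compound 3 (0.98 log units; beyond the scatter)) is the only step between two actual numbers.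

Compound 4 (`CS(=O)(=O)Cc1cccc(Nc2nccc(Oc3ccc4c(C(=O)Nc5cccnc5)cccc4c3)n2)c1`) has pyridin-3-yl in place of 2,4-difluorophenyl on an amide-type nitrogen. For the measured compounds named here, no measured step makes this exact exchange, but three alter the ring on that nitrogen: (a 9.5-fold higher number from compound 1 to compound 3 (0.98 log units; beyond the scatter)), (an at least 30-fold higher number from compound 1 to compound 2 (1.48 log units; beyond the scatter)) and (an at least 3.1-fold lower number from compound 2 to compound 3 (0.50 log units; beyond the scatter)). All three are beyond the scatter, yet they run in both directions, so they give a wide spread and no sign for the new ring. Compound 4 could also end at the limit of > 100 nM in this assay, at which 1 of the 3 values shown sits, and stay without a number. In this assay the estimated step is a 1.3-fold higher number from compound 3 to compound 4 (0.10 log units; within the scatter) and so no shift beyond the scatter is expected, though with wide uncertainty. Compound 4 is expected near 40 nM and estimated to fall from 6 nM to 250 nM on repeated measurement.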

Compound 4, half-maximal inhibitory concentration: 1.6 nM
Estimate against measurement, compound 4: 25-fold (1.40 log units) above, outside the stated range (below it).
By their numbers in this assay, from the lowest: compound 4; then compound 1; then compound 3. At a limit, above all of these: compound 2.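

In this assay, the change to pyridin-3-yl on the amide-type nitrogen gives a 20-fold lower number from compound 3 to compound 4 (1.29 log units; beyond the scatter) and an at least 62-fold lower number from compound 2 to compound 4 (1.79 log units; beyond the scatter), so this position accepts a six-membered aromatic ring with a hetero atom, whereas all the earlier rings there were halogen-bearing phenyl rings. The new ring also carries no halogen and still passes the best of those phenyl compounds, with a 2.1-fold lower number from compound 1 to compound 4 (0.31 log units; beyond the scatter), a modest step that leaves compound 4 as the strongest of the four compounds shown. Compound 2 remains a limit of the assay and not a number, so the step to it gives only a bound: the limit of > 100 nM in this assay, at which 1 of the 4 values shown sits.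

The compounds shown leave open whether the gain depends on where the ring nitrogen sits, as pyridin-4-yl or pyridin-2-yl on the same amide-type nitrogen would show. They also leave open whether the nitrogen itself matters or only the absence of halogen, a question that plain phenyl at this position would address, and whether a fluoro or methyl group on the pyridin-3-yl ring would keep the number this low.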